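This account rests on a few compounds, and the source may have more. Where it says the series, first, only, none or still open, it means among the compounds named here.

In a functional assay on MKN-45 cells (Homo sapiens) for cytotoxicity, read by MTT assay, with a stated time of 48 h (on this read-out lower numbers stand for stronger inhibition and higher numbers for weaker inhibition), compound 1 `COc1ccc(/C=N/n2c(SC)nnc2-c2cc(OC)c(OC)c(OC)c2)c(OC)c1` gives > 200000 nM, a limit of the assay. Compound 2 `COc1ccc(/C=N/n2c(SCc3ccccc3Cl)nnc2-c2cc(OC)c(OC)c(OC)c2)c(OC)c1` gives > 200000 nM, again a limit. Compound 3 `COc1ccc(/C=N/n2c(SCc3ccccc3)nnc2-c2cc(OC)c(OC)c(OC)c2)c(OC)c1` gives 49000 nM.

Among the measured compounds shown here, compound 3 thus holds the only number among the three; the other two sit at the limit of > 200000 nM in this assay, at which 2 of the 3 values shown sit. Compound 4 `CCOC(=O)CSc1nnc(-c2cc(OC)c(OC)c(OC)c2)n1/N=C/c1ccc(OC)cc1OC` differs from compound 3 by ethoxycarbonyl in place of phenyl on a saturated chain carbon bound to a sulfur. For the measured compounds named here, the only readable step at this carbon is an at least 4.0-fold lower number from compound 1 to compound 3 (0.61 log units; beyond the scatter), so removing the phenyl toward hydrogen pushes the number back to the limit, while a step that the two limits leave unreadable from compound 1 to compound 2 cannot be sized. Going by the values given here, no measured step replaces phenyl with ethoxycarbonyl, so the expectation rests on the phenyl alone carrying the gain, and a weaker, higher number is expected, a 2.4-fold higher number from compound 3 to compound 4 (0.39 log units; beyond the scatter). Compound 4 is therefore estimated at 120000 nM, between 30000 nM and 200000 nM.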

Compound 4, half-maximal inhibitory concentration: > 200000 nM
Compound 4: only a limit was reported; the forecaster's own chance of this, stated with the estimate: 50%; middle value at least 1.6-fold (0.22 log units) away from the limit.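

Placing ethoxycarbonyl instead of phenyl on this saturated chain carbon bound to a sulfur gives an at least 4.0-fold higher number from compound 3 to compound 4 (0.61 log units; beyond the scatter). So the gain seen with compound 3 does not come with just any group at this carbon, and phenyl remains the only group shown here that gives a number. The steps among compound 1, compound 2 and compound 4 cannot be read, so these three cannot be ranked, because each value is a limit: the limit of > 200000 nM in this assay, at which 3 of the 4 values shown sit.

As far as these compounds go, whether a carboxylic acid, an amine or a plain butyl chain at this carbon would give a number stays open.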